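The source may report more compounds than this note shows. Statements on the series, on what has been measured and on what is new or still open speak of the compounds shown alone.

Three compounds have so far been measured in a functional assay on ECa-109 cells (Homo sapiens) for cytotoxicity, read by MTT assay, with a stated time of 72 h; a lower number here means a stronger inhibitor, a higher number a weaker inhibitor:

Compound 1, `COc1ccc(Nc2cc(C)nc(SCc3nc4ccccc4[nH]3)n2)cc1`, gives 69800 nM
Compound 2, `Cc1cc(Nc2ccc(Cl)cc2)nc(SCc2nc3ccccc3[nH]2)n1`, gives 20400 nM
Compound 3, `Cc1ccc(Nc2cc(C)nc(SCc3nc4ccccc4[nH]3)n2)cc1`, gives 57300 nM

Compound 3 stands second highest of these three numbers. Its nearest neighbour is compound 1, and that step, a 1.2-fold lower number from compound 1 to compound 3 (0.09 log units; within the scatter), is within the scatter, so the two cannot be ordered. Its furthest neighbour is compound 2, and that step, a 2.8-fold higher number from compound 2 to compound 3 (0.45 log units; beyond the scatter), is a modest one beyond the scatter.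

Compound 4, `Cc1cc(Nc2ccc(F)cc2)nc(SCc2nc3ccccc3[nH]2)n1`, differs from compound 3 in one place: fluoro in place of methyl on an aromatic carbon. Among the measured compounds shown here, no measured step swaps a methyl for a fluoro, so the bearing of the earlier steps is indirect. Two of them touch the same position: a 3.4-fold lower number from compound 1 to compound 2 (0.53 log units; beyond the scatter) gave a modest lowering, and a 2.8-fold higher number from compound 2 to compound 3 (0.45 log units; beyond the scatter) a modest rise, both beyond the scatter, while a 1.2-fold lower number from compound 1 to compound 3 (0.09 log units; within the scatter) stayed within it. Chloro is the only halogen measured here, and fluoro has not been tested, so the direction is uncertain; a lowering no larger than the chloro step seems the most likely outcome, with a result within the scatter also possible.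

Compound 4 is therefore expected to give about 35000 nM, with a likely range from 15000 nM to 80000 nM. The expected step is a 1.6-fold lower number from compound 3 to compound 4 (0.21 log units; within the scatter).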

Compound 4, half-maximal inhibitory concentration: 69500 nM
Estimate against measurement, compound 4: 2.0-fold (0.30 log units) below; measured number inside the range.
By their numbers in this assay, from the lowest: compound 2; then compounds 3, 4 and 1 (each within the scatter of the next).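

Swapping the 4-methylphenyl group for 4-fluorophenyl (a 1.2-fold higher number from compound 3 to compound 4 (0.08 log units; within the scatter)) brings no readable change in this assay, and replacing methoxy with fluoro at the same place (a 1.0-fold lower number from compound 1 to compound 4 (0.00 log units; within the scatter)) also stays within the scatter, so methyl, methoxy and fluoro cannot be ordered here. Halogens do not act as one class at this place among the compounds shown: the modest lowering seen with chloro does not appear with fluoro, and the step back from chloro (a 3.4-fold higher number from compound 2 to compound 4 (0.53 log units; beyond the scatter)) lies beyond the scatter, leaving compound 2 alone as the strongest of the four. No measurement shown here explains why chloro stands apart from fluoro at this place.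

Going by these compounds, whether bromo or iodo would follow chloro, and how a nitrile, a trifluoromethyl group or an amine would compare at this place, remains open. On these data alone, all four compounds also share one core, so it is unknown whether the difference between chloro and fluoro would hold if another part of the core carried a different group, such as a carboxylic acid.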